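Sulfone versus thioether pair, trifluoromethyl for fluoro

The source may hold more compounds than are shown below. What is called first, only, known or untested is meant among the compounds shown, and "the series" means these compounds.

Four compounds share a hydroxy-amide backbone carrying a pentafluorosulfanyl-substituted anilide. Compound 1 `CC(O)(CSc1ccc(F)cc1)C(=O)Nc1cccc(S(F)(F)(F)(F)F)c1` bears a thioether to a 4-fluorophenyl group; compound 2 `CC(O)(CSc1ccc(C(F)(F)F)cc1)C(=O)Nc1cccc(S(F)(F)(F)(F)F)c1` is its partner with a trifluoromethyl in place of fluoro on an aromatic carbon, (trifluoromethyl in place of fluoro on an aromatic carbon). Compound 3 `CC(O)(CS(=O)(=O)c1ccc(F)cc1)C(=O)Nc1ccc(S(F)(F)(F)(F)F)cc1` carries a sulfone to a 4-fluorophenyl group on a core whose difference from the core of compound 1 is not broken down here. Compound 4 `CC(O)(CS(=O)(=O)c1ccc(C(F)(F)F)cc1)C(=O)Nc1ccc(S(F)(F)(F)(F)F)cc1` is the unmeasured sulfone partner, (trifluoromethyl in place of fluoro on an aromatic carbon), the same change as from compound 1 to compound 2, at a place described in the same words.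

In a functional assay on CWR22R cells (Homo sapiens) for antiproliferative activity, read by propidium iodide staining, with a stated time of 96 h (on this read-out higher numbers stand for weaker inhibition and lower numbers for stronger inhibition), compound 1 gives 30200 nM and compound 2 gives 26900 nM, a step of a 1.1-fold lower number from compound 1 to compound 2 (0.05 log units; within the scatter). Compound 3 gives 20600 nM in this assay, a value that sits within the scatter of both compound 1 and compound 2.

For compound 4 the step in this assay is expected to be a 1.1-fold lower number from compound 3 to compound 4 (0.05 log units; within the scatter), resting on the essentially flat step a 1.1-fold lower number from compound 1 to compound 2 (0.05 log units; within the scatter) seen with the same change. Compound 4 is therefore estimated at 18500 nM, with a range from 9000 nM to 40000 nM.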

Compound 4, half-maximal inhibitory concentration: 28900 nM
The estimate for compound 4 lay 1.6-fold (0.19 log units) below the measured number; low and high end bracket the measured number.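

In this assay, exchanging 4-fluorophenyl for 4-(trifluoromethyl)phenyl on the sulfone core gives a 1.4-fold higher number from compound 3 to compound 4 (0.15 log units; within the scatter), so this step, like the one on the thioether core, stays within the scatter. Set side by side, the two steps do not differ: the same change on two cores in this assay, a 1.1-fold lower number (0.05 log units; within the scatter) from compound 1 to compound 2 and a 1.4-fold higher number (0.15 log units; within the scatter) from compound 3 to compound 4, 1.6-fold (0.20 log units) apart, within the scatter of two such steps. Among the compounds shown here, this shows that the change leaves the number within the scatter on both cores, but it does not show that a real effect carries from one core to the other, and the core of compound 1 and the core of compound 3 differ in more than the sulfone, so no step for the sulfone alone can be read.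

Open, on these data alone, is whether another group in place of fluoro, such as a nitrile, an amine or a carboxylic acid, would give a step beyond the scatter on either core. Also open, as far as these compounds go, is whether the thioether and the sulfone compare alike on one and the same anilide, and what a methoxy in place of the hydroxy group would do.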